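The source may hold more compounds than are shown below. What is called first, only, known or untested is meant among the compounds shown, and "the series" means these compounds.

Working notes on the series

Compound 1 `c1ccc(CNCC2CCN(CCCc3c[nH]c4ccc(-n5cnnc5)cc34)CC2)cc1` gives 101% in a functional assay on CHO cells for activation of 5-hydroxytryptamine receptor 1D (Homo sapiens), read by GTPgammaS binding (a lower number here means a smaller maximal response, a higher number a larger maximal response), and is the highest of the three measured numbers; its nearest neighbour is compound 3 `C[C@@H](NC1CCN(CCCc2c[nH]c3ccc(-n4cnnc4)cc23)CC1)c1ccccc1` with 90%, the furthest is compound 2 `c1ccc2c(c1)CCC2NC1CCN(CCCc2c[nH]c3ccc(-n4cnnc4)cc23)CC1` with 68%. Both measured steps away from compound 1 go downward and beyond the scatter: a number 33 percentage points lower from compound 1 to compound 2 (beyond the scatter) and a number 11 percentage points lower from compound 1 to compound 3 (beyond the scatter). Between the two, a number 22 percentage points higher from compound 2 to compound 3 (beyond the scatter).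

The next compound, compound 4 `CC(CO)(NC1CCN(CCCc2c[nH]c3ccc(-n4cnnc4)cc23)CC1)c1ccccc1`, differs from compound 1 by (1-(hydroxymethyl)-1-phenylethyl)amino in place of (benzylamino)methyl on a saturated ring carbon. The step from compound 1 to compound 3 is the closer precedent, since there too the amine carbon gains a methyl and the benzylamino link is shortened; compound 4 goes further, carrying a hydroxymethyl on the same carbon. The indanyl case shows that a bulkier group on this nitrogen can cost much more. A downward step is therefore expected for compound 4, of a size between the two precedents, estimated as a number 23 percentage points lower from compound 1 to compound 4 (beyond the scatter). The estimate for compound 4 is 78%, with a range of 58% to 96%.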

Compound 4, largest response reached (reported as efficacy), in percent of the reference or control that the assay uses: 59%
Compound 4: the middle estimate sits 19 percentage points above what was measured, within the range that was stated.
By their numbers in this assay, from the lowest: compounds 4 and 2 (each within the scatter of the next); then compound 3; then compound 1.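

In this assay, placing a hydroxymethyl on the amine-bearing carbon of the 1-phenylethyl group carries a large cost of its own: a number 31 percentage points lower from compound 3 to compound 4 (beyond the scatter), and overall a number 42 percentage points lower from compound 1 to compound 4 (beyond the scatter). The open-chain 1-(hydroxymethyl)-1-phenylethyl group also gives a response level in line with the 2,3-dihydro-1H-inden-1-yl group, a number 9 percentage points lower from compound 2 to compound 4 (within the scatter), so among these compounds a reduced maximal response on this amine nitrogen is not confined to the latter group. Nothing at hand bears on the reason for the fall.

Whether the oxygen or simply the added carbon accounts for the change remains open, and an ethyl, a methoxymethyl or an aminomethyl on the same carbon would separate the two. Also open, on these data alone, is whether a carboxylic acid there would lower the response further or restore it.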